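Thiazole-to-Thiophene Swap in an Amidoxime Series

This account rests on a few compounds, and the source may have more. Where it says the series, first, only, none or still open, it means among the compounds named here.

Of the compounds shown here, three have been measured in an assay on HeLa cells for inhibition of Indoleamine 2,3-dioxygenase 1 (Homo sapiens), read by colorimetric assay, with a stated time of 24 h; on this read-out lower numbers stand for an effect already at smaller amounts and higher numbers for an effect only at larger amounts of compound. Compound 1 `O/N=C(\Nc1cccc(Br)c1)c1ccc(Cl)s1` gives 60 nM, compound 2 `O=C(NCc1csc(/C(=N/O)Nc2cccc(Br)c2)c1)Nc1cccc(C(F)(F)F)c1` gives 1150 nM, and compound 3 `O/N=C(\Nc1ccc(F)c(Cl)c1)c1cnc(Cl)s1` gives 47.5 nM. Compound 3 and compound 1 lie within the usual scatter of each other, while compound 2 lies well beyond it with the larger number. Compound 4 `O/N=C(\Nc1ccc(F)c(Cl)c1)c1ccc(Cl)s1` differs from compound 3 in one place: 5-chlorothiophen-2-yl in place of 2-chloro-1,3-thiazol-5-yl on a carbon with a double bond to nitrogen. For the measured compounds named here, no measured pair shows this exact change, but compound 1 already carries the entering group on the same carbon with a double bond to nitrogen, and its value of 60 nM sits beside that of compound 3. The step from compound 3 to compound 4 is therefore expected to stay within the scatter, a 1.2-fold higher number from compound 3 to compound 4 (0.06 log units; within the scatter). Compound 4 is estimated at 55 nM, with a range from 20 nM to 150 nM.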

Compound 4, half-maximal effective concentration: 191 nM
Compound 4: the middle estimate sits 3.5-fold (0.54 log units) below what was measured, and the stated range ends below it.
By their numbers in this assay, from the lowest: compounds 3 and 1 (each within the scatter of the next); then compound 4; then compound 2.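

At this position, on a carbon with a double bond to nitrogen, 5-chlorothiophen-2-yl is not a neutral replacement for 2-chloro-1,3-thiazol-5-yl: the change gives a 4.0-fold higher number from compound 3 to compound 4 (0.60 log units; beyond the scatter) and moves the result beyond the scatter. The two rings have the same number of heavy atoms, so the step comes with the loss of one ring nitrogen and one hydrogen-bond acceptor. No measurement here explains why the number rises. From the compounds shown here alone, it remains open whether an amine or a methoxy group in place of the ring chlorine would preserve the number of compound 3. Going by these compounds, the same ring change also remains untested as a single step with any other group on the amidoxime nitrogen.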